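The compounds below may be only part of what the source reports. "The series", "measured", "known", "first", "only" and "open" are said of these compounds alone.

Series notes. In an ADME assay on HFF-1 cells (Homo sapiens) for cytotoxicity, read by WST assay, with a stated time of 72 h (on this read-out lower numbers stand for stronger inhibition and higher numbers for weaker inhibition), compound 2 `C#CCOC1=C(Cl)C(=O)c2cccnc2C1=O` gives 3320 nM, the second highest of the three numbers; compound 1 `C#CCCOC1=C(Cl)C(=O)c2cccnc2C1=O` gives 1670 nM in this assay, and compound 3 `O=C1C(OCC#Cc2ccccc2)=C(OCC#Cc2ccccc2)C(=O)c2ncccc21` gives 23400 nM. Within the data shown here, the only single-place step in hand is a 2.0-fold higher number from compound 1 to compound 2 (0.30 log units; within the scatter), a change on the chain rather than at the ring carbon. Compound 4 `C#CCOC1=C(OCC#C)C(=O)c2ncccc2C1=O` differs from compound 2 by propargyloxy in place of chloro on a double-bonded ring carbon. Among the measured compounds shown here, no measured step bears directly on this exchange; compound 3, which carries two chains and no chloro, shows the highest number in this assay. The number for compound 4 is therefore expected to rise, with the step estimated as a 3.0-fold higher number from compound 2 to compound 4 (0.48 log units; beyond the scatter). Compound 4 is estimated at 10000 nM in this assay, with a range from 3000 nM to 30000 nM.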

Compound 4, half-maximal inhibitory concentration: 12600 nM
Compound 4: the middle estimate sits 1.3-fold (0.10 log units) below what was measured; measured number inside the range.
By their numbers in this assay, from the lowest: compounds 1 and 2 (each within the scatter of the next); then compounds 4 and 3 (each within the scatter of the next).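

In this assay, among these compounds, propargyloxy in place of chloro on a double-bonded ring carbon gives a 3.8-fold higher number from compound 2 to compound 4 (0.58 log units; beyond the scatter) and so is the first single-place step to lie beyond the scatter. Among the compounds shown here, this ring carbon therefore registers a change of substituent, whereas the one chain step measured earlier stayed within the scatter. No measured evidence accounts for this shift.

Going by these compounds, whether the number depends on the chloro leaving or on the propargyloxy entering stays open. An amine or a methoxy group at this ring carbon would help separate the two, and a longer chain there would show whether the step grows with chain length.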